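Notes on the aryl ketone end of the stilbene-chalcone series

The compounds below may be only part of what the source reports. "The series", "measured", "known", "first", "only" and "open" are said of these compounds alone.

The shared core is the stilbene-chalcone of compound 1 `COc1ccc(/C=C/c2cc(OC)cc(OC)c2/C=C/C(=O)c2ccccc2)cc1`, whose antiproliferative activity in a functional assay on B16-F10 cells (Mus musculus) for antiproliferative activity, read by MTT assay, with a stated time of 48 h (a lower number here means a stronger inhibitor, a higher number a weaker inhibitor), is 3.7 ug/mL. Compound 2 `CCCC(C)Oc1ccc(C(=O)/C=C/c2c(/C=C/c3ccc(OC)cc3)cc(OC)cc2OC)cc1` carries a 1-methylbutoxy in place of hydrogen on an aromatic carbon of the ketone-bearing ring and gives 6.7 ug/mL. Among the two measured numbers compound 2 has the highest, though the step of a 1.8-fold higher number from compound 1 to compound 2 (0.26 log units; within the scatter) keeps it within the scatter of compound 1, so the two cannot be ordered.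

Compound 3 `COc1ccc(/C=C/c2cc(OC)cc(OC)c2/C=C/C(=O)c2ccc(C)c(C)c2)cc1` is not yet measured. It differs from compound 2 by 3,4-dimethylphenyl in place of 4-(1-methylbutoxy)phenyl on a carbonyl carbon. For the measured compounds named here, the one measured step that bears on this position, a 1.8-fold higher number from compound 1 to compound 2 (0.26 log units; within the scatter), showed that a change on the ketone-bearing ring moved the number by no more than the scatter. On that basis no step beyond the scatter is expected in this assay for the exchange to compound 3, in either direction; the expected step is a 1.3-fold lower number from compound 2 to compound 3 (0.13 log units; within the scatter).

For compound 3 the estimated value in this assay is therefore 5 ug/mL, with a range from 2.5 ug/mL to 10 ug/mL.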

Compound 3, half-maximal inhibitory concentration: 1.4 ug/mL
Beside the measured number, compound 3's estimate is 3.6-fold (0.55 log units) above it, outside the stated range (below it).
By their numbers in this assay, from the lowest: compound 3; then compounds 1 and 2 (each within the scatter of the next).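

In this assay, the aryl group on the carbonyl carbon now produces steps beyond the scatter: the exchange of 4-(1-methylbutoxy)phenyl for 3,4-dimethylphenyl gives a 4.8-fold lower number from compound 2 to compound 3 (0.68 log units; beyond the scatter), and the exchange of phenyl for 3,4-dimethylphenyl gives a 2.6-fold lower number from compound 1 to compound 3 (0.42 log units; beyond the scatter). Both steps are modest, but they show that this position is not silent, as the pair of compound 1 and compound 2, which lie within the scatter of each other, had left it looking, and that the 3,4-dimethylphenyl group separates compound 3 from both of them. Nothing at hand accounts for this difference.

The compounds shown leave open whether one methyl group on the phenyl ring would give the same step as the two in compound 3, and whether the result extends to other groups at this place, such as a chlorophenyl, an aminophenyl or a phenyl carrying a carboxylic acid. Also open, going by these compounds, is whether a shorter chain, such as a methoxy in place of the 1-methylbutoxy, would stay within the scatter of compound 2 or move towards compound 3.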